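Working notes: a fluoro step on compound 2

The source may hold more compounds than are shown below. What is called first, only, known or untested is meant among the compounds shown, and "the series" means these compounds.

Measured so far in a functional assay on MCF7 cells (Homo sapiens) for inhibition, read by MTT assay, with a stated time of 72 h; a higher number here means a weaker inhibitor, a lower number a stronger inhibitor
compound 1 `COc1cc(NC(=O)/C=C/c2cccc(OCc3ccccc3)c2)cc(OC)c1OC` gives 2400 nM
compound 2 `C=C(Br)C(=O)Nc1cccc(/C=C/C(=O)Nc2ccccc2)c1` gives 27300 nM
compound 3 `C=C(Br)C(=O)Nc1cccc(/C=C/C(=O)Nc2cccc3ccccc23)c1` gives 2800 nM

Compound 2 (27300 nM) holds the highest number of the three, which makes it the weakest inhibitor in this small set. Compound 1 and compound 3 both lie lower by more than the scatter, and their two values cannot be told apart.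

Next to be read is compound 4 `C=C(Br)C(=O)Nc1cccc(/C=C/C(=O)Nc2ccc(F)cc2)c1` in this assay and it comes from compound 2 by a single change (fluoro in place of hydrogen on an aromatic carbon), with fluoro in place of hydrogen on an aromatic carbon, para to a large group. Within the data shown here, no two measured compounds differ in one place, so the series offers no direct measure of this change, and the expectation carries little support from the data. For so small a change, only a modest move towards a lower number is expected, and it may stay within the scatter. The estimated step is a 1.6-fold lower number from compound 2 to compound 4 (0.21 log units; within the scatter) and its direction remains uncertain. The estimated value for compound 4 is 17000 nM (expected range 7000 nM to 40000 nM).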

Compound 4, half-maximal inhibitory concentration: 13600 nM
Estimate against measurement, compound 4: 1.3-fold (0.10 log units) above; the measured number falls inside the stated range.
By their numbers in this assay, from the lowest: compounds 1 and 3 (each within the scatter of the next); then compounds 4 and 2 (each within the scatter of the next).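

Among these compounds, this is the first direct reading of a single change: in this assay, going from phenyl to 4-fluorophenyl gives a 2.0-fold lower number from compound 2 to compound 4 (0.30 log units; within the scatter), so the step cannot be separated from repeat-measurement noise. Fluoro in place of hydrogen on this aromatic carbon, para to a large group, is therefore accepted here without a loss of inhibition beyond the scatter, and this place on the anilino ring can carry a substituent of one heavy atom with the rest of compound 2 unchanged. No supporting measurement is available that could explain the reading, and nothing here separates a small real effect of the fluoro from no effect at all.

A single small substituent at one carbon says little about how far this place can be pushed, and a chloro, methoxy, trifluoromethyl or dimethylamino group at the same carbon would show whether any group here moves the number beyond the scatter. Also open, going by these compounds, is whether fluoro on the other carbons of this ring reads the same way, and whether a carboxylic acid or an amine is accepted on this ring at all.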